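This account rests on a few compounds, and the source may have more. Where it says the series, first, only, none or still open, it means among the compounds named here.

Working notes on the series

Of the compounds shown here, three around the shared core have been measured. In an assay on brain for binding affinity to Neuronal acetylcholine receptor; alpha4/beta2 (Rattus norvegicus), read by radioligand binding (a higher number here means a weaker inhibitor, a lower number a stronger inhibitor), compound 1 `Fc1ccc(OC[C@@H]2CCN2)cn1` gives 0.057 nM. Compound 2 `COc1ccc(OC[C@@H]2CCN2)cn1` carries a methoxy where compound 1 carries a fluoro. In this assay compound 2 gives 1.3 nM; the step of a 23-fold higher number from compound 1 to compound 2 (1.36 log units; beyond the scatter) is the one large movement seen so far. Compound 3 `Nc1cncc(OC[C@@H]2CCN2)c1` gives 0.082 nM in this assay, the second highest of the three numbers: its gap to compound 1 lies within the scatter, while compound 2 sits well above it.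

Compound 4 `NCc1cncc(OC[C@@H]2CCN2)c1` is compound 3 with one change, (aminomethyl in place of amino on an aromatic carbon), on an aromatic carbon of a six-membered aromatic ring with 1 nitrogen, two atoms from the ring nitrogen. Among the measured compounds shown here, no measured step in this assay covers this kind of exchange: the only step at hand, from compound 1 to compound 2, concerns different groups at a different carbon, so it gives no direct guide. The donor and acceptor count is unchanged and only one carbon enters, so a step of modest size is expected, most likely toward a somewhat higher number, and possibly none beyond the scatter.

For compound 4 the expected step is a 3.0-fold higher number from compound 3 to compound 4 (0.48 log units; beyond the scatter). Compound 4 is therefore estimated at 0.25 nM in this assay, with a range from 0.05 nM to 1.5 nM.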

Compound 4, inhibition constant: 4.4 nM
Beside the measured number, compound 4's estimate is 18-fold (1.25 log units) below it, outside the stated range (above it).
By their numbers in this assay, from the lowest: compounds 1 and 3 (each within the scatter of the next); then compound 2; then compound 4.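

In this assay, a 54-fold higher number from compound 3 to compound 4 (1.73 log units; beyond the scatter) shows that this carbon, two atoms from the ring nitrogen, is sensitive even to a small exchange: one added carbon is enough for a large step, although the groups that leave and enter have the same hydrogen-bond donor and acceptor counts and neither carries a net charge. Among the compounds shown here, this is the first step measured at this carbon and the second large step, so aminomethyl cannot be treated as a close substitute for amino at this place on the shared core. Nothing at hand gives a measured reason for the size of the step.

Going by these compounds, it remains open whether the step follows the added carbon alone or the placing of the amine one carbon further from the aromatic ring, a question that a methyl or hydroxymethyl group at this carbon could help to separate. A longer chain such as aminoethyl would show whether the number keeps rising with chain length or whether the change is complete with aminomethyl.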